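The source may hold more compounds than are shown below. What is called first, only, known or untested is meant among the compounds shown, and "the series" means these compounds.

Compounds measured so far:

compound 1 `COc1ccc(/C=C/C(=O)c2c(C)[n+]([O-])c3ccccc3[n+]2[O-])cc1`: 92000 nM
compound 2 `COc1ccc(/C=C/C(=O)c2c(C)[n+]([O-])c3ccccc3[n+]2[O-])cc1OC`: 142000 nM
compound 3 `Cc1c(C(=O)/C=C/c2ccc(Cl)cc2)[n+]([O-])c2ccccc2[n+]1[O-]`: 21000 nM

All numbers come from an ADME assay on HPC cells (Homo sapiens) for cytotoxicity, with a stated time of 48 h; a higher number here means that more compound is tolerated, a lower number that less compound is tolerated. Compound 3 stands lowest of the three; the step of a 4.4-fold lower number from compound 1 to compound 3 (0.64 log units; beyond the scatter) is beyond the scatter, and the gap to compound 2 is wider still.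

Compound 4 `Cc1c(C(=O)/C=C/c2ccc(Cl)c(Cl)c2)[n+]([O-])c2ccccc2[n+]1[O-]` differs from compound 3 by chloro in place of hydrogen on an aromatic carbon. Within the data shown here, two measured steps bear on this. Among the measured compounds shown here, the one step that adds a methoxy group to compound 1, a 1.5-fold higher number from compound 1 to compound 2 (0.19 log units; within the scatter), stays within the scatter. For the measured compounds named here, the one step involving chloro, a 4.4-fold lower number from compound 1 to compound 3 (0.64 log units; beyond the scatter), is a modest fall, though there chloro replaced methoxy rather than hydrogen. A small step downward or none beyond the scatter is therefore expected in this assay.

Compound 4 is estimated at 14000 nM, with a range of 6000 nM to 35000 nM. The expected step is a 1.5-fold lower number from compound 3 to compound 4 (0.18 log units; within the scatter).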

Compound 4, half-maximal cytotoxic concentration: 13000 nM
Beside the measured number, compound 4's estimate is 1.1-fold (0.03 log units) above it, and the stated range covers the measured number.
By their numbers in this assay, from the lowest: compounds 4 and 3 (each within the scatter of the next); then compounds 1 and 2 (each within the scatter of the next).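

In this assay, adding a second chloro ortho to the existing chloro group leaves the number within the scatter (a 1.6-fold lower number from compound 3 to compound 4 (0.21 log units; within the scatter)), so hydrogen and chloro are not separated here on a ring that already carries chloro. The change from 4-methoxyphenyl to 3,4-dichlorophenyl gives a step beyond the scatter (a 7.1-fold lower number from compound 1 to compound 4 (0.85 log units; beyond the scatter)). No measurement available here accounts for either step.

On these data alone, it remains open whether an amine or a carboxylic acid in this place would move the number beyond the scatter. Also open, as far as these compounds go, is how chloro here behaves on a ring without the first chloro.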